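Series notes: compound 3 to compound 4

A few compounds are considered here, and "the series" means these few. Any claim that something is new, unique, unknown or untested is made for them only; others in the source may bear on it.

Compound 1 `COc1cc(NC(C)CCCNC(=O)Nc2ccc(Br)cc2)c2ncccc2c1`: 25000 nM
Compound 2 `COc1cc(NC(C)CCCNC(=O)Nc2ccc(F)cc2)c2ncccc2c1`: 24000 nM
Compound 3 `COc1cc(NC(C)CCCNC(=O)Nc2cccc(O)c2)c2ncccc2c1`: 24000 nM

All three values come from a functional assay on MOLT-4 cells (Homo sapiens) for inhibition, read by MTT assay, with a stated time of 72 h; on this read-out lower numbers stand for stronger inhibition and higher numbers for weaker inhibition. Compound 3 stands level with compound 2, and neither it nor compound 2 separates from compound 1. The measured steps are a 1.0-fold lower number from compound 1 to compound 2 (0.02 log units; within the scatter), a 1.0-fold lower number from compound 1 to compound 3 (0.02 log units; within the scatter) and no change at the digits printed from compound 2 to compound 3 (within the scatter), all within the scatter.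

Compound 4 `COc1cc(NC(C)CCCNC(=O)NNC(=O)Nc2cccc(Cl)c2)c2ncccc2c1` has not yet been measured. It replaces the 3-hydroxyphenyl of compound 3 with ((3-chlorophenyl)carbamoyl)amino, on the amide-type nitrogen whose other neighbour is the carbonyl carbon: ((3-chlorophenyl)carbamoyl)amino in place of 3-hydroxyphenyl on an amide-type nitrogen.

The three measured steps bear on this change only in part. They exchange 4-bromophenyl, 4-fluorophenyl and 3-hydroxyphenyl on that nitrogen, and none of them introduces the carbamoyl-bearing amino unit. Going by the values given here, that part of the change therefore has no measured precedent, which calls for a wide range. Among these three compounds, no change at the digits printed from compound 2 to compound 3 (within the scatter) and a 1.0-fold lower number from compound 1 to compound 3 (0.02 log units; within the scatter) give no reason to expect a large shift in this assay from compound 3 at 24000 nM.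

The estimated step is a 1.2-fold lower number from compound 3 to compound 4 (0.08 log units; within the scatter), with no change expected beyond the scatter. The expected value for compound 4 is 20000 nM. The estimated range for compound 4 runs from 8000 nM to 50000 nM.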

Compound 4, half-maximal inhibitory concentration: 93000 nM
Compound 4: the middle estimate sits 4.7-fold (0.67 log units) below what was measured; measured number above the stated range.
By their numbers in this assay, from the lowest: compounds 2, 3 and 1 (each within the scatter of the next); then compound 4.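

The position on the amide-type nitrogen whose other neighbour is the carbonyl carbon had looked flat in this assay, since 4-bromophenyl, 4-fluorophenyl and 3-hydroxyphenyl all stayed within the scatter of one another. Going by these compounds alone, compound 4 shows that this flatness does not hold for every group there: ((3-chlorophenyl)carbamoyl)amino gives a 3.9-fold higher number from compound 3 to compound 4 (0.59 log units; beyond the scatter), and the same direction appears as a 3.9-fold higher number from compound 2 to compound 4 (0.59 log units; beyond the scatter) and as a 3.7-fold higher number from compound 1 to compound 4 (0.57 log units; beyond the scatter), so this is the first change at the position to move the number beyond the scatter, and it moves it towards weaker inhibition. No measurement at hand explains this shift.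

The compounds shown do not separate the contribution of the added carbamoyl-bearing amino unit from that of the chlorine, and a plain 3-chlorophenyl on the same nitrogen would be the direct comparison with compound 3. Also open, as far as these compounds go, is how this assay responds at this position to a phenyl ring carrying an amine or a carboxylic acid, or to a longer chain in place of the amino unit.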